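This account rests on a few compounds, and the source may have more. Where it says the series, first, only, none or still open, it means among the compounds named here.

Measured so far:
- compound 1, `O=S(=O)(Nc1ccc(F)c(Cl)c1)c1ccc(-c2cnc(C3CC3)o2)cc1`: 73700 nM
- compound 2, `O=S(=O)(Nc1cc(Cl)ccc1Cl)c1ccc(-c2cnc(C3CC3)o2)cc1`: > 100000 nM
- compound 3, `COc1cc(NS(=O)(=O)c2ccc(-c3cnc(C4CC4)o3)cc2)ccc1F`: 75700 nM

In a functional assay on cells (leukaemia cell line, Homo sapiens) for inhibition, read by sulforhodamine B assay, with a stated time of 48 h (a lower number here means a stronger inhibitor of growth, a higher number a weaker inhibitor of growth), compound 1 gives 73700 nM, the lower of the two numbers obtained. Compound 3, the nearest, sits within scatter of it, the step being a 1.0-fold higher number from compound 1 to compound 3 (0.01 log units; within the scatter). Compound 2 returns only a limit of this assay, (the limit of > 100000 nM in this assay, at which 1 of the 3 values shown sits), and not a number. The step of an at least 1.3-fold higher number from compound 1 to compound 2 (0.13 log units; that floor lies within the scatter) therefore has only a floor, one that lies within the scatter, as does an at least 1.3-fold lower number from compound 2 to compound 3 (0.12 log units; that floor lies within the scatter).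

Compound 4 is `Cc1cc(Cl)cc(NS(=O)(=O)c2ccc(-c3cnc(C4CC4)o3)cc2)c1`. It differs from compound 1 as 3-chloro-5-methylphenyl in place of 3-chloro-4-fluorophenyl on a sulfonamide nitrogen. The measured steps that bear on it are those that swap the group on the sulfonamide nitrogen: an at least 1.3-fold higher number from compound 1 to compound 2 (0.13 log units; that floor lies within the scatter) and an at least 1.3-fold lower number from compound 2 to compound 3 (0.12 log units; that floor lies within the scatter), neither resolved beyond the scatter, and the single-atom change a 1.0-fold higher number from compound 1 to compound 3 (0.01 log units; within the scatter), which is flat. Across the three compounds the numbers in this assay do not move beyond scatter whatever group stands on the sulfonamide nitrogen. For compound 4 no step beyond the scatter is expected in this assay, the estimated step being a 1.0-fold higher number from compound 1 to compound 4 (0.01 log units; within the scatter). Compound 4 is thus estimated at 75000 nM, with a range of 35000 nM to 160000 nM, and a real chance that this assay again reports only a limit.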

Compound 4, concentration for total growth inhibition: 7040 nM
The estimate for compound 4 lay 11-fold (1.03 log units) above the measured number, and the stated range ends above it.
By their numbers in this assay, from the lowest: compound 4; then compounds 1 and 3 (each within the scatter of the next). At a limit, above all of these: compound 2.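

In this assay, for the compounds shown here, the group on the sulfonamide nitrogen now proves able to move the number beyond the scatter: 3-chloro-5-methylphenyl gives a 10-fold lower number from compound 1 to compound 4 (1.02 log units; beyond the scatter) and an 11-fold lower number from compound 3 to compound 4 (1.03 log units; beyond the scatter), whereas no earlier step between compounds 1, 2 and 3 resolved beyond it. The step from compound 2 also clears the scatter, at an at least 14-fold lower number from compound 2 to compound 4 (1.15 log units; beyond the scatter), but it is only a floor, since compound 2 holds a limit and not a number: the limit of > 100000 nM in this assay, at which 1 of the 4 values shown sits. The large step from the 3-chloro-4-fluorophenyl group comes with one fluorine leaving and one carbon entering, and with no change in the hydrogen-bond donors, hydrogen-bond acceptors or net charge counted for the group.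

The compounds shown do not separate the gain of the methyl group from the loss of the fluorine, or either of these from the change in where the groups stand on the ring, and they give no cause for the step. From the compounds shown here alone, how an ethyl group, an amine or a carboxylic acid in place of that methyl group would read in this assay remains open.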